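This account rests on a few compounds, and the source may have more. Where it says the series, first, only, none or still open, it means among the compounds named here.

Working notes on the series. Compound 1 `O=C(CN1CCCCC1)Nc1ccc(-c2nc3cc(C(F)(F)F)ccc3[nH]2)cc1` has been measured in an ADME assay on Vero cells (Chlorocebus sabaeus) for cytotoxicity (a higher number here means that more compound is tolerated, a lower number that less compound is tolerated), and gives 31000 nM, the lowest of the three numbers in hand. Compound 2 `COc1ccc(-c2nc3cc(C(F)(F)F)ccc3[nH]2)c(N)c1` gives 50000 nM in this assay; its gap to compound 1 is within the scatter, so the two are read as one level. Compound 3 `COc1ccc(-c2nc3cc(Cl)c(Cl)cc3[nH]2)c(N)c1` gives 75000 nM in this assay, a higher number than compound 1 by a gap that goes beyond the scatter. For the measured compounds named here, no two of these three compounds differ in only one place, so no single step between measured compounds is available as a guide.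

Compound 4 `Cn1c(-c2ccc(NC(=O)CN3CCCCC3)cc2)nc2cc(C(F)(F)F)ccc21` has not yet been measured in this assay. It differs from compound 1 as follows: methyl in place of hydrogen on an aromatic nitrogen. The change is one carbon on an aromatic nitrogen of the shared core, and the three numbers in hand give no ground to expect a large move from it. The step from compound 1 to compound 4 is expected to be a 1.0-fold lower number from compound 1 to compound 4 (0.01 log units; within the scatter), which is taken to stay within the scatter in either direction. Compound 4 is therefore estimated in this assay at 30000 nM, with a range from 12000 nM to 75000 nM.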

Compound 4, half-maximal cytotoxic concentration: > 100000 nM
Compound 4: a limit, no number (the forecaster's own chance of this, stated with the estimate: 10%); at least 3.3-fold (0.52 log units) between middle value and limit.
By their numbers in this assay, from the lowest: compounds 1, 2 and 3 (each within the scatter of the next, the first and the last beyond it). At a limit, above all of these: compound 4.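

In this assay compound 4 gives > 100000 nM, which is a limit of the assay and not a number. For the compounds shown here, the methyl on the aromatic nitrogen of the shared core gives the only single-place step, an at least 3.2-fold higher number from compound 1 to compound 4 (0.50 log units; beyond the scatter), and it shows that this nitrogen is not a silent position here: one carbon in place of the hydrogen, with the rest of compound 1 unchanged, is enough to carry the read-out beyond the scatter. The step is a lower bound only, and its true size cannot be stated: the limit of > 100000 nM in this assay, at which 1 of the 4 values shown sits.

From the compounds shown here alone, the change is seen on this one pair only, so it remains open whether the same methyl would give a step of this kind on compound 2 or compound 3, which both keep the hydrogen on that nitrogen. Going by these compounds, it is also open whether the result is specific to methyl or would carry over to an ethyl group, a longer chain or an acetyl group on the same nitrogen.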